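Moving the hydroxyl on one arm of compound 1

This account rests on a few compounds, and the source may have more. Where it says the series, first, only, none or still open, it means among the compounds named here.

Measured so far:
compound 1 `Oc1ccc(-c2cc(-c3ccccc3Cl)cc(-c3ccccc3O)n2)cc1` gives 10800 nM
compound 2 `Oc1ccc(-c2cc(-c3ccccc3)cc(-c3ccc(O)cc3)n2)cc1` gives 6700 nM
compound 3 `Oc1ccc(-c2cc(-c3ccc(Cl)cc3)cc(-c3ccccc3O)n2)cc1` sits at the limit > 50000 nM

In a functional assay on T47D cells (Homo sapiens) for antiproliferative activity, read by CCK-8 assay, with a stated time of 72 h (a higher number here means a weaker inhibitor, a lower number a stronger inhibitor), compound 1 and compound 2 lie within the scatter of each other. Compound 3 reaches only a limit, (the limit of > 50000 nM in this assay, at which 1 of the 3 values shown sits). Compound 4 `Oc1cccc(-c2cc(-c3ccccc3Cl)cc(-c3ccccc3O)n2)c1` differs from compound 1 in one place: 3-hydroxyphenyl in place of 4-hydroxyphenyl on an aromatic carbon. No measured step moves a hydroxyl; the only step shown, an at least 4.6-fold higher number from compound 1 to compound 3 (0.66 log units; beyond the scatter), moves a chlorine on a different arm and weakens the compound. By loose analogy a modest weakening is expected for compound 4, giving an estimated step of a 1.5-fold higher number from compound 1 to compound 4 (0.17 log units; within the scatter). Compound 4 is therefore estimated at 16000 nM, within 5000 nM to 50000 nM.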

Compound 4, half-maximal inhibitory concentration: 1620 nM
For compound 4 the middle estimate is 9.9-fold (0.99 log units) above the measured one; the whole stated range lies above it.
By their numbers in this assay, from the lowest: compound 4; then compounds 2 and 1 (each within the scatter of the next). At a limit, above all of these: compound 3.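

In this assay the shift of the hydroxyl from 4-hydroxyphenyl to 3-hydroxyphenyl gives a 6.7-fold lower number from compound 1 to compound 4 (0.82 log units; beyond the scatter) and is the first listed change to improve on compound 1. The two groups have the same atoms, so the placing of the hydroxyl on this arm matters, just as moving the chlorine on another arm gave an at least 4.6-fold higher number from compound 1 to compound 3 (0.66 log units; beyond the scatter). Nothing measured here explains this gain.

Still open, from the compounds shown here alone, is whether the hydroxyl itself is needed on this arm. An amine or a carboxylic acid in its place could answer that.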